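A Second Fluorine on the Aryl Ring of Compound 2

This account rests on a few compounds, and the source may have more. Where it says the series, first, only, none or still open, it means among the compounds named here.

Three compounds share one core. In a functional assay on CHO cells for positive allosteric modulation of metabotropic glutamate receptor 2 (Homo sapiens), with a stated time of 30 min (on this read-out lower numbers stand for an effect already at smaller amounts and higher numbers for an effect only at larger amounts of compound), compound 1 `CCCCn1ccc(N2CCC(c3ccccc3)CC2)c(C#N)c1=O` gives 95 nM, compound 2 `N#Cc1c(N2CCC(c3ccc(F)cc3)CC2)ccn(CC2CC2)c1=O` gives 89 nM, and compound 3 `N#Cc1c(N2CCC(c3cccc(C(F)(F)F)c3)CC2)ccn(CC2CC2)c1=O` gives 46 nM. The number for compound 2 is the second highest of the three, yet it sits within the usual scatter of both compound 1 and compound 3, so the three cannot be told apart with confidence. Compound 4 `N#Cc1c(N2CCC(c3ccc(F)cc3F)CC2)ccn(CC2CC2)c1=O` differs from compound 2 by one change: fluoro in place of hydrogen on an aromatic carbon. For the measured compounds named here, no measured pair shows this change, so the step from compound 2 to compound 4 in this assay is expected to be small and within the scatter, a 1.2-fold lower number from compound 2 to compound 4 (0.07 log units; within the scatter). Compound 4 is therefore estimated at 75 nM, with a range from 30 nM to 190 nM.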

Compound 4, half-maximal effective concentration: 68 nM
Beside the measured number, compound 4's estimate is 1.1-fold (0.04 log units) above it, within the range that was stated.
By their numbers in this assay, from the lowest: compounds 3, 4, 2 and 1 (each within the scatter of the next, the first and the last beyond it).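

In this assay, for the compounds shown here, adding fluoro on the aromatic carbon ortho to a large group gives a 1.3-fold lower number from compound 2 to compound 4 (0.12 log units; within the scatter), the first step here between two compounds that differ in one place. The step lies within the scatter, so turning 4-fluorophenyl into 2,4-difluorophenyl leaves the read-out indistinguishable from that of compound 2 and shows that this position tolerates fluoro. No supporting evidence bears on this result.

Going by these compounds, whether chloro, methoxy or an amine on this same carbon would move the number beyond the scatter remains open. So does whether fluoro at this position would give a similar step on the unsubstituted phenyl ring of compound 1.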